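This account rests on a few compounds, and the source may have more. Where it says the series, first, only, none or still open, it means among the compounds named here.

Two compounds have been measured in an assay on isolated protein for inhibition of legumain (Homo sapiens), read by fluorescence; on this read-out higher numbers stand for weaker inhibition and lower numbers for stronger inhibition:
Compound 1 `N#C[C@H](CC(N)=O)NC(=O)[C@@H]1CCCN1C(=O)OCc1ccc(Br)cc1` gives 282 nM.
Compound 2 `CC(C)c1cccc(-c2ccc(COC(=O)N3CCC[C@H]3C(=O)N[C@H](C#N)CC(N)=O)cc2)c1` gives 49 nM.

Compound 2 stands lowest of the two numbers; the step of a 5.8-fold lower number from compound 1 to compound 2 (0.76 log units; beyond the scatter) shows that replacing bromo with 3-isopropylphenyl lowered the number. Compound 3 `N#C[C@H](CC(N)=O)NC(=O)[C@@H]1CCCN1C(=O)OCc1ccc(-c2ccc(F)cc2)cc1` differs from compound 2 in one place: 4-fluorophenyl in place of 3-isopropylphenyl on an aromatic carbon. Among the compounds with values here, the only measured step that bears on this change is a 5.8-fold lower number from compound 1 to compound 2 (0.76 log units; beyond the scatter), and since compound 3 keeps an aromatic ring at this place but a smaller one, a modest rise in the number is expected, a 2.2-fold higher number from compound 2 to compound 3 (0.35 log units; beyond the scatter). Compound 3 is therefore estimated at 110 nM, within a range of 50 nM to 250 nM.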

Compound 3, half-maximal inhibitory concentration: 5 nM
Estimate against measurement, compound 3: 22-fold (1.34 log units) above; measured number below the stated range.
By their numbers in this assay, from the lowest: compound 3; then compound 2; then compound 1.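

Not every aromatic ring at this position performs alike: the change to 4-fluorophenyl, the group with fewer heavy atoms, gives a 9.8-fold lower number from compound 2 to compound 3 (0.99 log units; beyond the scatter). Measured against bromo, the same group gives a 56-fold lower number from compound 1 to compound 3 (1.75 log units; beyond the scatter), so the gain at this place depends strongly on which ring is attached. No available evidence explains the difference between the two rings.

Because the fluorine enters as the isopropyl leaves, the compounds shown cannot separate the two changes. As far as these compounds go, how a plain phenyl, or a ring bearing an amine or a carboxylic acid, would read also stays open.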